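From one drawn configuration to its mirror image

A few compounds are considered here, and "the series" means these few. Any claim that something is new, unique, unknown or untested is made for them only; others in the source may bear on it.

Compound 1, `CC(C)[C@H](NC(=S)NCc1ccccc1)c1nc2ccccc2[nH]1`, gives 49900 nM in a functional assay on HeLa cells (Homo sapiens) for cytotoxicity, read by MTT assay; on this read-out higher numbers stand for weaker inhibition and lower numbers for stronger inhibition.
Compound 2, `CC(C)C[C@H](NC(=S)NCc1ccccc1)c1nc2ccccc2[nH]1`, gives 31200 nM in this assay.
Compound 3, `CC(C)C[C@H](NC(=S)Nc1ccccc1)c1nc2ccccc2[nH]1`, gives 29100 nM in this assay.

Compound 2 stands second highest of the three numbers in this assay. Its nearest neighbour is compound 3, reached through a 1.1-fold lower number from compound 2 to compound 3 (0.03 log units; within the scatter), and its furthest is compound 1, separated by a 1.6-fold lower number from compound 1 to compound 2 (0.20 log units; within the scatter). Both steps lie within the usual scatter, so these three compounds cannot be ordered against one another on the numbers shown.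

Compound 4, `CC(C)C[C@@H](NC(=S)NCc1ccccc1)c1nc2ccccc2[nH]1`, is the next compound to be measured. Compared with compound 2, (the two compounds have the same atoms and bonds and differ only in configuration as drawn: 1 of 1 stereo elements differ; a stereocentre at a saturated chain carbon is drawn S in compound 2 and R in compound 4). Nothing is added and nothing is removed; only the drawn handedness at that carbon is changed.

Neither measured step bears on this change. One replaces isopropyl with isobutyl, the other replaces benzyl with phenyl, and both leave the configuration untouched. Among the measured compounds shown here, no measured pair differs only in configuration, so the effect of this inversion is simply unknown. The expectation therefore rests on compound 2 alone and must carry a wide range in both directions.

Compound 4 is expected to give about 35000 nM, with a range from 12000 nM to 100000 nM. That estimate means an expected step of a 1.1-fold higher number from compound 2 to compound 4 (0.05 log units; within the scatter), essentially none beyond the scatter, though a real difference in either direction cannot be excluded.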

Compound 4, half-maximal inhibitory concentration: 21200 nM
Estimate against measurement, compound 4: 1.7-fold (0.22 log units) above; the measured number falls inside the stated range.
By their numbers in this assay, from the lowest: compounds 4, 3, 2 and 1 (each within the scatter of the next, the first and the last beyond it).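

Turning the stereocentre at the saturated chain carbon from S to R gives a 1.5-fold lower number from compound 2 to compound 4 (0.17 log units; within the scatter) in this assay, so the two forms cannot be told apart on this read-out. Among the compounds shown here, the earlier steps swapped one group for another and left the drawn configuration as it was, so they could say nothing about the handedness of this carbon; this pair is the first direct reading of it, and that reading is clean because no other structural difference could contribute to the step: the fact that compounds 2 and 4 differ only in the configuration as drawn. With an isobutyl group on this carbon and a benzyl group on the thiourea-type nitrogen, then, the drawn handedness has no effect that stands out from the usual scatter of repeated measurements.

Going by these compounds, the result covers this one pair only, so it remains open whether handedness would also leave the number within the scatter with isopropyl on the same carbon, as in compound 1, or with phenyl on the nitrogen, as in compound 3. On these data alone, it is equally open how either form would respond if a carboxylic acid, an amine or a longer chain took the place of the isobutyl group.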